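Nitro in place of dimethylamino: what to expect

The compounds below may be only part of what the source reports. "The series", "measured", "known", "first", "only" and "open" are said of these compounds alone.

Compound 1 `COc1ccc(/C=C/C(=O)NS(=O)(=O)c2ccccc2)cc1`: 13.2 ug/mL
Compound 2 `CN(C)c1ccc(/C=C/C(=O)NS(=O)(=O)c2ccccc2)cc1`: 2.3 ug/mL

Both compounds were tested in a functional assay on B16-F10 cells (Mus musculus) for antiproliferative activity, read by ELISA and MTT assay, with a stated time of 48 h; a higher number here means a weaker inhibitor, a lower number a stronger inhibitor. Within the data shown here, compound 2 holds the lower of the two numbers, and the only measured step, a 5.7-fold lower number from compound 1 to compound 2 (0.76 log units; beyond the scatter), separates it from compound 1, its nearest neighbour; that step lies beyond the usual scatter.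

Compound 3 `O=C(/C=C/c1ccc([N+](=O)[O-])cc1)NS(=O)(=O)c1ccccc1` differs from compound 2 by nitro in place of dimethylamino on an aromatic carbon. Among the measured compounds shown here, the change sits at the same place as the one measured step, so that step is the only one that bears on it. It shows that exchanging the group on this aromatic carbon can move the number well beyond the scatter, but it does not include nitro, so neither its direction nor its size can be carried over with confidence. Because compound 2 gained its standing through a 5.7-fold lower number from compound 1 to compound 2 (0.76 log units; beyond the scatter), a move back toward the number of compound 1 is the plainer expectation. Compound 3 is therefore expected to give a weaker result, a step of about a 3.9-fold higher number from compound 2 to compound 3 (0.59 log units; beyond the scatter). The estimate for compound 3 is 9 ug/mL, with a range from 3 ug/mL to 30 ug/mL.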

Compound 3, half-maximal inhibitory concentration: 4.8 ug/mL
Compound 3: the middle estimate sits 1.9-fold (0.27 log units) above what was measured; the range from low to high includes it.
By their numbers in this assay, from the lowest: compound 2; then compound 3; then compound 1.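

In this assay, placing nitro on this aromatic carbon gives a 2.1-fold higher number from compound 2 to compound 3 (0.32 log units; beyond the scatter) and, measured against methoxy, a 2.8-fold lower number from compound 1 to compound 3 (0.44 log units; beyond the scatter) on the same shared core. The position now has three groups in a clear order: compound 2 with dimethylamino gives the lowest number, compound 3 with nitro comes next, and compound 1 with methoxy gives the highest, with every gap beyond the usual scatter. Dimethylamino and nitro each have 3 heavy atoms, so in this pair an equal count of heavy atoms does not bring an equal number, and no measurement shown here accounts for the order.

Among these compounds, with only three groups at this position, it remains open where a simple amine, a carboxylic acid, a halogen such as chlorine or a longer chain such as diethylamino would fall in this order. As far as these compounds go, it is also open whether the same order would hold with a different group in place of the benzene attached to the sulfonyl part of the molecule.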